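Working notes: from compound 1 to compound 4

The source may report more compounds than this note shows. Statements on the series, on what has been measured and on what is new or still open speak of the compounds shown alone.

Compound 1 `CC(=O)N(C(C)=O)c1ccc(-c2nc3ccccc3s2)cc1` gives > 100 nM as a limit
Compound 2 `CC(=O)N(C(C)=O)c1ccc(-c2nc3ccccc3s2)cc1C` gives > 10000 nM as a limit
Compound 3 `CC(=O)N(C(C)=O)c1ccc(-c2nc3ccccc3s2)cc1Cl` gives > 10000 nM as a limit

All three values come from a functional assay on MCF7 cells (Homo sapiens) for antiproliferative activity (on this read-out lower numbers stand for stronger inhibition and higher numbers for weaker inhibition), and are limits, not numbers. Compound 1 stands at the limit of > 100 nM in this assay, at which 1 of the 3 values shown sits, and so has no number of its own. Compound 2 and compound 3 stand together at the limit of > 10000 nM in this assay, at which 2 of the 3 values shown sit, as their shared limit.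

Compound 4 `O=C(CCl)Nc1ccc(-c2nc3ccccc3s2)cc1` is still unmeasured. The change to it is ((chloromethyl)carbonyl)amino in place of diacetylamino on an aromatic carbon and the core of compound 1 stays as it is. The measured steps are a step that the two limits leave unreadable from compound 1 to compound 2 and a step that the two limits leave unreadable from compound 1 to compound 3 and a step that the two limits leave unreadable from compound 2 to compound 3 and none of them alters the diacetylamino group. They offer no readable size or direction for this change. The expectation of weak inhibition rests only loosely on compound 2 at > 10000 nM as a limit. The estimate means a step that the limit leaves unreadable from compound 1 to compound 4 as an expected step of very uncertain size. Compound 4 is expected at 3000 nM in an estimated range from 200 nM to 30000 nM in this series.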

Compound 4, half-maximal inhibitory concentration: > 10 nM
Compound 4 was reported as a limit; the forecaster's own chance of this, stated with the estimate: 40%; the middle value lies beyond the limit too.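

In this assay compound 4 gives > 10 nM as a limit. For the compounds shown here, compound 1 gives > 100 nM as a limit too, so no step from compound 1 to compound 4 can be read. As far as these compounds go, it remains open whether ((chloromethyl)carbonyl)amino in place of diacetylamino strengthens or weakens inhibition, and by how much.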